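Removing a Ring Methyl from a Sulfone Analogue at the Limit

The source may hold more compounds than are shown below. What is called first, only, known or untested is meant among the compounds shown, and "the series" means these compounds.

Measured so far in a functional assay on PC-3 cells (Homo sapiens) for antiproliferative activity, read by MTT assay, with a stated time of 48 h; a higher number here means a weaker inhibitor, a lower number a stronger inhibitor:
compound 1 `COc1ccc2nc(Nc3ccnc(Nc4ccc(S(N)(=O)=O)cc4)n3)sc2c1`: 3030 nM
compound 2 `Cc1ccc2nc(Nc3ccnc(Nc4ccc(S(C)(=O)=O)cc4)n3)sc2c1`: > 50000 nM
compound 3 `NS(=O)(=O)c1ccc(Nc2ncc(F)c(Nc3nc4ccc(Cl)cc4s3)n2)cc1`: 1430 nM

Of the three, compound 1 and compound 3 return numbers, and the two differ in more than one place, so only their two values can be set side by side. Compound 2 stands apart: in this assay compound 2 gives > 50000 nM, which is a limit of the assay and not a number. Its position is the limit of > 50000 nM in this assay, at which 1 of the 3 values shown sits.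

The compound still to be measured, compound 4 `CS(=O)(=O)c1ccc(Nc2nccc(Nc3nc4ccccc4s3)n2)cc1`, differs from compound 2 by hydrogen in place of methyl on an aromatic carbon. For the measured compounds named here, no pair among the measured compounds shows this change on its own, so nothing here tells how large such a step has been before. Since compound 2 sits at the limit, any step beyond the scatter that the assay could register from compound 2 to compound 4 can only run toward a stronger number. The author expects at most a modest move of that kind, with a fair chance that compound 4 also returns only a limit. The step from compound 2 to compound 4 is expected to be an at least 1.6-fold lower number from compound 2 to compound 4 (0.22 log units; that floor lies within the scatter). Compound 4 is therefore estimated at 30000 nM, within a range from 8000 nM to 50000 nM.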

Compound 4, half-maximal inhibitory concentration: 1710 nM
Compound 4: middle estimate off by 18-fold (1.24 log units), on the high side, and the stated range ends above it.
By their numbers in this assay, from the lowest: compounds 3, 4 and 1 (each within the scatter of the next, the first and the last beyond it). At a limit, above all of these: compound 2.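

Exchanging methyl for hydrogen on this aromatic carbon, meta to a fused ring and para to a fused ring, gives an at least 29-fold lower number from compound 2 to compound 4 (1.46 log units; beyond the scatter) in this assay. For the compounds shown here, this is the first reading of the change at this position, and it shows that this one exchange, with the rest of the structure unchanged, separates a compound at the limit from one that returns a number. Compound 2 gives > 50000 nM as a limit and not a number, so the step has only a floor and its full size cannot be read: the limit of > 50000 nM in this assay, at which 1 of the 4 values shown sits.

The compounds shown leave open whether hydrogen is special at this aromatic carbon or whether other groups there, such as an ethyl group, a hydroxyl or an amine, would also return a number in this assay. They also leave open whether the same exchange would shift a compound that starts from a number rather than a limit, and they offer no measured basis for naming a cause of the step.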